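The source may report more compounds than this note shows. Statements on the series, on what has been measured and on what is new or still open speak of the compounds shown alone.

Measured so far:
- compound 1 `COc1cc(/C=C2\CN(C)C/C(=C\c3ccc(Br)cc3)C2=O)cc(OC)c1`: 5900 nM
- compound 2 `COc1cc(/C=C2\CN(C)C/C(=C\c3cccc([N+](=O)[O-])c3)C2=O)cc(OC)c1`: 2560 nM

In a functional assay on HeLa cells (Homo sapiens) for cytotoxicity, read by MTT assay, with a stated time of 24 h (a higher number here means a weaker inhibitor, a lower number a stronger inhibitor), compound 2 has the lower of the two numbers, at 2560 nM. Next in the series is compound 3 `COc1cc(/C=C2\CN(C)C/C(=C\c3ccc(C#N)cc3)C2=O)cc(OC)c1`, which has 4-cyanophenyl in place of 3-nitrophenyl on a double-bonded chain carbon bound to a double-bonded ring carbon.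

For the measured compounds named here, only one measured step bears on this change: a 2.3-fold lower number from compound 1 to compound 2 (0.36 log units; beyond the scatter). It is modest but beyond the scatter, and it was made at the same place, with 3-nitrophenyl replacing 4-bromophenyl. Going by the values given here, the new change also removes 3-nitrophenyl, but no measured compound carries 4-cyanophenyl, so that single step is only a loose guide. A small shift in this assay towards the value of compound 1 seems most likely, and it may not clear the scatter.

The expected change is a 1.4-fold higher number from compound 2 to compound 3 (0.15 log units; within the scatter), towards a higher number. For compound 3 the estimated value is 3600 nM, with an expected range of 1500 nM to 8000 nM.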

Compound 3, half-maximal inhibitory concentration: 3420 nM
Beside the measured number, compound 3's estimate is 1.1-fold (0.02 log units) above it; the measured number falls inside the stated range.
By their numbers in this assay, from the lowest: compounds 2, 3 and 1 (each within the scatter of the next, the first and the last beyond it).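

In this assay, replacing 3-nitrophenyl with 4-cyanophenyl on a double-bonded chain carbon bound to a double-bonded ring carbon gives a 1.3-fold higher number from compound 2 to compound 3 (0.13 log units; within the scatter), while cyano in place of bromo on an aromatic carbon gives a 1.7-fold lower number from compound 1 to compound 3 (0.24 log units; within the scatter). Compound 3 therefore cannot be separated from either compound 1 or compound 2, although those two remain apart by a 2.3-fold lower number from compound 1 to compound 2 (0.36 log units; beyond the scatter). At this place the three aryl groups span a narrow range, with only the two ends of the series resolved, and nothing available here accounts for the numbers.

Because 3-nitrophenyl differs from the other two groups in both its substituent and its name-given ring position, the shown compounds leave open whether the nitro group or its placement drives the separation of compound 2 from compound 1, a question that 4-nitrophenyl or 3-cyanophenyl at the same place would address. Also open, on these data alone, is whether a markedly different substituent on this phenyl ring, such as an amine or a carboxylic acid, would move the number beyond the scatter from all three compounds.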